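A few compounds are considered here, and "the series" means these few. Any claim that something is new, unique, unknown or untested is made for them only; others in the source may bear on it.

Compound 1, `Cc1ccc(C(=O)CCN2CCN(c3ccc(Cl)cc3)CC2)cc1`: 184000 nM
Compound 2, `Cc1ccc(C(=O)CCN2CCN(c3ccc([N+](=O)[O-])cc3)CC2)cc1`: 235000 nM
Compound 3, `COc1ccc(C(=O)CCN2CCN(c3ccc(Cl)cc3)CC2)cc1OC`: 185000 nM

The three measured compounds were tested in an ADME assay on Vero cells (Chlorocebus sabaeus) for cytotoxicity, read by resazurin assay, with a stated time of 72 h; on this read-out lower numbers stand for stronger inhibition and higher numbers for weaker inhibition. Compound 1 gives 184000 nM there, compound 2 gives 235000 nM, and compound 3 gives 185000 nM. Compounds 1 and 3 carry different cores; the difference between the two cores is not broken down here. Compound 1 and compound 2 differ in one place, (nitro in place of chloro on an aromatic carbon), and this change gave a 1.3-fold higher number from compound 1 to compound 2 (0.11 log units; within the scatter).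

Compound 4, `COc1ccc(C(=O)CCN2CCN(c3ccc([N+](=O)[O-])cc3)CC2)cc1OC`, has not yet been measured in this assay. It stands to compound 3 as compound 2 stands to compound 1: the change is nitro in place of chloro on an aromatic carbon, the same change at the same kind of place. Because the earlier step of a 1.3-fold higher number from compound 1 to compound 2 (0.11 log units; within the scatter) stayed within the scatter, the step from compound 3 to compound 4 is expected to be of similar size, a 1.3-fold higher number from compound 3 to compound 4 (0.11 log units; within the scatter), resting on that single earlier pair and on the value of compound 3, 185000 nM. On that basis compound 4 is estimated to give 240000 nM in this assay, with a range from 150000 nM to 380000 nM.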

Compound 4, half-maximal inhibitory concentration: 105000 nM
The estimate for compound 4 lay 2.3-fold (0.36 log units) above the measured number; the measured number lies below the stated range.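

In this assay, nitro in place of chloro on the core of compound 3 gave a 1.8-fold lower number from compound 3 to compound 4 (0.25 log units; within the scatter), and this step does not part from the earlier one on the core of compound 1 by more than the scatter allows: the same change on two cores in this assay, a 1.3-fold higher number (0.11 log units; within the scatter) from compound 1 to compound 2 and a 1.8-fold lower number (0.25 log units; within the scatter) from compound 3 to compound 4, 2.3-fold (0.35 log units) apart, within the scatter of two such steps. This shows that, at the resolution of this cytotoxicity read-out, the change carries from one core to the other without a detectable difference, and that on neither core does it move the number beyond the scatter. Among these compounds, it does not show that the change acts identically on both cores: the comparison rests on only two pairs, and the opposite directions of the two steps cannot be told apart from scatter.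

Going by these compounds, whether an amine or a carboxylic acid on that same aromatic carbon would move the number beyond the scatter remains open. Also open, on these data alone, is whether the chloro-to-nitro step would stay this small on a third core, such as one with a longer chain in place of the methyl of compound 1.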